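The source may report more compounds than this note shows. Statements on the series, on what has been measured and on what is new or still open speak of the compounds shown alone.

Measured compounds:
- compound 1 `CCCCCc1ccc(NS(=O)(=O)c2ccc(N3CCNC3=O)cc2)cc1`: 990 nM
- compound 2 `O=C1NCCN1c1ccc(S(=O)(=O)Nc2cccc(Br)c2)cc1`: 77 nM
- compound 3 `O=C1NCCN1c1ccc(S(=O)(=O)Nc2ccc(OC(F)F)cc2)cc1`: 650 nM

All three share one core and differ only in the group carried on the outer aromatic ring. In a functional assay on HT-29 cells (Homo sapiens) for antiproliferative activity, read by sulforhodamine B assay, with a stated time of 48 h (a lower number here means a stronger inhibitor, a higher number a weaker inhibitor), compound 3 gives 650 nM, the second highest of the three numbers. Within the data shown here, its nearest neighbour is compound 1, and the only recorded step, a 1.5-fold lower number from compound 1 to compound 3 (0.18 log units; within the scatter), shows that swapping pentyl for difluoromethoxy changed little. Compound 2, which carries a bromo group instead, gives a far lower number, and the two values stand well apart.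

Compound 4 `O=C1NCCN1c1ccc(S(=O)(=O)Nc2ccc(Br)cc2)cc1` is the next step: bromo in place of difluoromethoxy on an aromatic carbon. Among the measured compounds shown here, the one measured step bears on it only indirectly, since it involves a different pair of groups and lay within the scatter. For the measured compounds named here, what the values of compound 2 and compound 3 show is that a bromo-bearing analogue can sit much lower than the difluoromethoxy compound, though no step links the two directly.

For compound 4, therefore, a lower number than compound 3 is expected, by about a 2.6-fold lower number from compound 3 to compound 4 (0.41 log units; beyond the scatter), with wide uncertainty. The estimate for compound 4 in this assay is 250 nM, within a range from 80 nM to 800 nM.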

Compound 4, half-maximal inhibitory concentration: 300 nM
Compound 4: middle estimate off by 1.2-fold (0.08 log units), on the low side; measured number inside the range.
By their numbers in this assay, from the lowest: compound 2; then compound 4; then compounds 3 and 1 (each within the scatter of the next).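

The direct comparison shows that the identity of the group on this aromatic carbon matters in this assay: bromo in place of difluoromethoxy gives a 2.2-fold lower number from compound 3 to compound 4 (0.34 log units; beyond the scatter), a modest change but one that clears the usual scatter. Bromo in place of pentyl points the same way, with a 3.3-fold lower number from compound 1 to compound 4 (0.52 log units; beyond the scatter), so among these three compounds bromo gives the lowest number at this position, even though the pentyl and difluoromethoxy compounds cannot be told apart. Moving the bromo group also matters, since 4-bromophenyl in place of 3-bromophenyl on the sulfonamide nitrogen gives a 3.9-fold higher number from compound 2 to compound 4 (0.59 log units; beyond the scatter), which means that the low number of compound 2 depends on where the bromo group sits and not merely on its presence.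

No measurement available here explains why any of these numbers differ. Still open, as far as these compounds go, is how a chloro group, a methoxy group, an amine or a carboxylic acid would compare at this position, and whether groups other than bromo would also give a lower number at the ring position that carries bromo in compound 2.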